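Ethyl in place of trifluoromethyl on compound 2

This account rests on a few compounds, and the source may have more. Where it says the series, first, only, none or still open, it means among the compounds named here.

Measured so far in a functional assay on A549 cells (Homo sapiens) for cytotoxicity, read by MTT assay, with a stated time of 72 h; on this read-out higher numbers stand for weaker inhibition and lower numbers for stronger inhibition:
Compound 1 `CCc1ccc(-c2cc(C(=O)Nc3ccc(Oc4ccnc(C(=O)NC)c4)cc3)ncn2)cc1` | 13300 nM
Compound 2 `CNC(=O)c1cc(Oc2ccc(NC(=O)c3cc(-c4ccc(C(F)(F)F)cc4)ncn3)cc2F)ccn1` | > 100000 nM

Compound 2 stands at > 100000 nM as a limit of the assay, not a number. Compound 3 `CCc1ccc(-c2cc(C(=O)Nc3ccc(Oc4ccnc(C(=O)NC)c4)c(F)c3)ncn2)cc1` carries ethyl in place of trifluoromethyl on an aromatic carbon, para to a large group (ethyl in place of trifluoromethyl on an aromatic carbon). A step toward lower numbers, meaning stronger inhibition, is expected, though its size stays loose: compound 2 has no number. The expectation rests on compound 1, which also bears 4-ethylphenyl and gives 13300 nM as its value. The expected step is an at least 5.0-fold lower number from compound 2 to compound 3 (0.69 log units; beyond the scatter) in this assay as a rough figure. Compound 3 is estimated at 20000 nM with 6000 nM to 70000 nM as its range.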

Compound 3, half-maximal inhibitory concentration: 3390 nM
Compound 3: the middle estimate sits 5.9-fold (0.77 log units) above what was measured; measured number below the stated range.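

In this assay, with the fluoro kept, ethyl in place of trifluoromethyl on this aromatic carbon gives an at least 29-fold lower number from compound 2 to compound 3 (1.46 log units; beyond the scatter), so the 4-ethylphenyl form reaches a number where the 4-(trifluoromethyl)phenyl form does not. That step is only a bound, as compound 2 stands at a limit of the assay and not at a number: the limit of > 100000 nM in this assay, at which 1 of the 3 values shown sits.

With 4-ethylphenyl held, fluoro in place of hydrogen adds its own gain, a 3.9-fold lower number from compound 1 to compound 3 (0.59 log units; beyond the scatter).

Going by these compounds, whether a longer chain such as propyl, or an amine, at this place would move the number further remains open. Also open, on these data alone, is how the fluoro step reads with trifluoromethyl in place of ethyl.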